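Aryl-piperazine amides of a shared imide core: next step

The source may report more compounds than this note shows. Statements on the series, on what has been measured and on what is new or still open speak of the compounds shown alone.

Compound 1 `CC1(c2ccccc2)CC(=O)N(CC(=O)N2CCOCC2)C1=O` carries a morpholine amide on the shared core and in a functional assay on the whole organism (strain CD-1) with Mus musculus as the target, in the maximal electroshock model, with a stated time of 2 h (a higher number here means that more compound is needed for the effect, a lower number that less compound is needed), compound 1 gives 300 mg/kg. Compound 2 `CC1(c2ccccc2)CC(=O)N(CC(=O)N2CCN(c3ccc(Cl)cc3)CC2)C1=O` replaces that morpholine with a piperazine bearing a 4-chlorophenyl group, and in this assay compound 2 is recorded as "not active" (no number reported); no single number stands for compound 2, so its place on the scale is only that no effect was found at the doses tried. Going by the values given here, no step between measured compounds can be given on this pair.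

Compound 3 `COc1cccc(N2CCN(C(=O)CN3C(=O)CC(C)(c4ccccc4)C3=O)CC2)c1` is the unmeasured analogue of compound 2 with the change (3-methoxyphenyl in place of 4-chlorophenyl on an amine nitrogen in a ring). The change is confined to the substituent on the amine nitrogen in the ring, and the counted difference is small. Among the compounds with values here, with compound 2 without a number and compound 1 the only quantified point, no direction for the step to compound 3 can be read from the data; the expectation is that compound 3 stays close to what compound 1 shows, or again yields no number. For compound 3 in this assay the estimated minimum effective dose is 300 mg/kg, with the likely range from 100 mg/kg to 600 mg/kg.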

Compound 3, minimum effective dose: "not active" (no number reported)
The entry for compound 3 holds no number; the estimate stays without a comparison.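

Compound 2 and compound 3 both carry no number in this assay, so no step can be read between them. No available evidence bears on this result. The compounds shown leave open whether any aryl-piperazine amide on the shared core gives a measurable dose in this assay, and how such a dose would compare with compound 1.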